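Benzyl on the Triazole Nitrogen: Compound 2 to Compound 3

The compounds below may be only part of what the source reports. "The series", "measured", "known", "first", "only" and "open" are said of these compounds alone.

Of the compounds shown here, two sharing one core have been measured so far. For the measured compounds named here, compound 1 `CC(=O)N[C@@H]1[C@@H](OC(C)=O)[C@H](OC(C)=O)[C@@H](COC(C)=O)O[C@H]1n1nc(-c2cc3ccccc3[nH]2)nc1SCc1ccccc1` is the first of them; in a functional assay on HepG2 cells (Homo sapiens) for antiproliferative activity, read by sulforhodamine B assay, with a stated time of 48 h (on this read-out lower numbers stand for stronger inhibition and higher numbers for weaker inhibition), compound 1 gives > 100 ug/mL, which is a limit of the assay rather than a number. Going by the values given here, compound 2 `c1ccc(CSc2nc(-c3cc4ccccc4[nH]3)n[nH]2)cc1` is the second; in this assay compound 2 gives 3.58 ug/mL, the only number among the two values shown. The other value, that of compound 1, is a limit of the assay, as the limit of > 100 ug/mL in this assay, at which 1 of the 2 values shown sits, records. Compound 3 `c1ccc(CSc2nc(-c3cc4ccccc4[nH]3)nn2Cc2ccccc2)cc1` differs from compound 2 by benzyl in place of hydrogen on an aromatic nitrogen. Among the compounds with values here, no measured step between two compounds differing in one place exists here, so the size of this step is open. A moderate weakening is expected, a 4.2-fold higher number from compound 2 to compound 3 (0.62 log units; beyond the scatter), somewhat beyond the scatter. Compound 3 is accordingly estimated at 15 ug/mL, within a range from 4 ug/mL to 60 ug/mL.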

Compound 3, half-maximal inhibitory concentration: 17.9 ug/mL
Estimate against measurement, compound 3: 1.2-fold (0.08 log units) below, and the stated range covers the measured number.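

Placing benzyl in place of hydrogen on the aromatic nitrogen, next to the ring atom that bears a benzylsulfanyl group, gives in this assay a 5.0-fold higher number from compound 2 to compound 3 (0.70 log units; beyond the scatter) and so yields the first size for a change at this position. Compound 1, which carries a different group on the same nitrogen, gives > 100 ug/mL as a limit of the assay and not a number. Compound 3 gives 17.9 ug/mL and shows that a group on this nitrogen can still leave a measurable value in this assay.

As far as these compounds go, whether a methyl group or a short chain ending in an amine on this nitrogen would lie nearer to compound 2 or to compound 3 remains open. The information given here does not bear on the cause of the step.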